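Vinyl in Place of Bromo: Expected Potency of Compound 4

The source may report more compounds than this note shows. Statements on the series, on what has been measured and on what is new or still open speak of the compounds shown alone.

The series is followed in an assay on isolated protein for inhibition of phosphatidylinositol 4,5-bisphosphate 3-kinase catalytic subunit beta isoform (Homo sapiens), read by 33P incorporation, with a stated time of 60 min; a higher number here means a weaker inhibitor, a lower number a stronger inhibitor. Compound 1 `CC(=O)Oc1ccn2ncc(/C=N/N(C)S(=O)(=O)c3cc([N+](=O)[O-])ccc3C)c2c1`, which carries an acetoxy group, reaches only the assay limit and gives > 1000 nM in this assay. Compound 2 `Cc1ccc([N+](=O)[O-])cc1S(=O)(=O)N(C)/N=C/c1cnn2cc(Br)ccc12` likewise stops at the limit, giving > 1000 nM. Among the compounds with values here, compound 3 `Cc1ccc([N+](=O)[O-])cc1S(=O)(=O)N(C)/N=C/c1cnn2ccc(Br)cc12` is the one member with a numbered result, 230 nM in this assay, and so it stands as the sole anchor for any comparison. Two of the three results sit at the limit of > 1000 nM in this assay, at which 2 of the 3 values shown sit. Within the data shown here, the only measured single-point step is an at least 4.3-fold lower number from compound 1 to compound 3 (0.63 log units; beyond the scatter), an improvement that moves a compound off the limit to a measured number. Among the measured compounds shown here, compound 2 and compound 3 share no single-point step; their two values can merely be set beside one another.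

Compound 4 `C=Cc1ccn2ncc(/C=N/N(C)S(=O)(=O)c3cc([N+](=O)[O-])ccc3C)c2c1` differs from compound 3 by vinyl in place of bromo on an aromatic carbon. For the measured compounds named here, no measured step exchanges bromo for a carbon group, so the expectation rests on compound 3 alone, with the vinyl group matching bromo in bringing no donors and no acceptors. The estimate for compound 4 in this assay is 350 nM. For compound 4 the expected range runs from 120 nM to 1000 nM. This estimate means an expected step of a 1.5-fold higher number from compound 3 to compound 4 (0.18 log units; within the scatter), not beyond the usual scatter.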

Compound 4, half-maximal inhibitory concentration: > 1000 nM
Compound 4: no number, only a limit (the forecaster's own chance of this, stated with the estimate: 25%); at least 2.8-fold (0.45 log units) between middle value and limit.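

In this assay, exchanging bromo for vinyl on this aromatic carbon, opposite the ring nitrogen, gives an at least 4.3-fold higher number from compound 3 to compound 4 (0.63 log units; beyond the scatter), so vinyl now joins acetoxy as a second group at this place that does not reach a measured number. Bromo and vinyl are alike in the hydrogen-bond donors and acceptors counted for them, so that count does not separate the two groups, although the step lies beyond the scatter. Compound 3 remains the only compound with a measured number, and the step between compound 1 and compound 4 cannot be read, which leaves most of the series at one limit: the limit of > 1000 nM in this assay, at which 3 of the 4 values shown sit.

The compounds shown leave open whether a chloro, a methyl or a small amine on this carbon would keep a measured number as bromo does. They also leave open whether a saturated ethyl chain or a carboxylic acid would fare any differently from vinyl and acetoxy.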